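The source may hold more compounds than are shown below. What is called first, only, known or untested is meant among the compounds shown, and "the series" means these compounds.

Compound 3 `COc1cccc(C(=O)Nc2ccc(Cl)cc2CN2C(=O)c3ccccc3C2=O)c1` is tested in an assay on CHO cells for positive allosteric modulation of metabotropic glutamate receptor 5 (Homo sapiens), read by FLIPR (on this read-out higher numbers stand for an effect only at larger amounts of compound and lower numbers for an effect already at smaller amounts), and gives 1500 nM. Its closest neighbour among the measured compounds is compound 1 `O=C(Nc1ccc(Cl)cc1CN1C(=O)c2ccccc2C1=O)c1ncccn1`, which in this assay gives 2100 nM, a gap that a 1.4-fold lower number from compound 1 to compound 3 (0.15 log units; within the scatter) puts within the scatter. Compound 2 `O=C(Nc1ccc(Cl)cc1CN1C(=O)c2ccccc2C1=O)c1cccnn1` reaches only a limit of the assay, > 100000 nM, which is the limit of > 100000 nM in this assay, at which 1 of the 3 values shown sits, rather than a number. The two steps that involve it are large: an at least 47-fold higher number from compound 1 to compound 2 (1.67 log units; beyond the scatter) and an at least 66-fold lower number from compound 2 to compound 3 (1.82 log units; beyond the scatter).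

Compound 4 `O=C(Nc1ccc(Cl)cc1CN1C(=O)c2ccccc2C1=O)c1ccccc1[N+](=O)[O-]` differs from compound 3 by a single exchange, (2-nitrophenyl in place of 3-methoxyphenyl on a carbonyl carbon). The three measured steps all swap the group on this same carbonyl carbon, so each bears on the question. One such swap, a 1.4-fold lower number from compound 1 to compound 3 (0.15 log units; within the scatter), changed almost nothing, while the two that touch compound 2 moved the number far. For the measured compounds named here, the new group keeps the six-membered aromatic ring of carbon only that compound 3 carries, so a modest change is the more likely outcome, yet a large one cannot be ruled out. Compound 4 is therefore expected to give 4000 nM, with a range from 1000 nM to 30000 nM. This corresponds to an expected 2.7-fold higher number from compound 3 to compound 4 (0.43 log units; beyond the scatter).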

Compound 4, half-maximal effective concentration: 5700 nM
The estimate for compound 4 lay 1.4-fold (0.15 log units) below the measured number; the range from low to high includes it.
By their numbers in this assay, from the lowest: compounds 3 and 1 (each within the scatter of the next); then compound 4. At a limit, above all of these: compound 2.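

For the compounds shown here, until now, the only group on this carbonyl carbon with a six-membered aromatic ring of carbon only was 3-methoxyphenyl, so compound 4 gives the first comparison between two such groups, and exchanging one for the other is not neutral: a 3.8-fold higher number from compound 3 to compound 4 (0.58 log units; beyond the scatter). The 2-nitrophenyl group also separates from pyrimidin-2-yl, a 2.7-fold higher number from compound 1 to compound 4 (0.43 log units; beyond the scatter), even though compounds 1 and 3 lie within the scatter of each other, so this position distinguishes between two groups that both still give a measurable number. The pyridazin-3-yl group, whose value is a limit and not a number, remains far from 2-nitrophenyl, with an at least 17-fold lower number from compound 2 to compound 4 (1.24 log units; beyond the scatter).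

Because the nitro group differs from methoxy in both identity and place on the ring, the compounds shown cannot separate these two changes, which 3-nitrophenyl or 2-methoxyphenyl would begin to do. How a plain phenyl, a cyclohexyl ring or a short alkyl chain would behave on this carbonyl carbon also stays open, and the true value of compound 2 stays unknown, as it sits at a limit: the limit of > 100000 nM in this assay, at which 1 of the 4 values shown sits.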